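The source may hold more compounds than are shown below. What is called first, only, known or untested is meant among the compounds shown, and "the series" means these compounds.

Compound 1 `CCS(=O)(=O)Nc1cc(-c2ccc3ncnc(Nc4ccc(OC)c(OC)c4)c3c2)cnc1OC` gives 2840 nM in a functional assay on SK-HEP1 cells (Homo sapiens) for cytotoxicity, read by sulforhodamine B assay, with a stated time of 72 h; a higher number here means a weaker inhibitor, a lower number a stronger inhibitor.
Compound 2 `CCCCS(=O)(=O)Nc1cc(-c2ccc3ncnc(Nc4cccc(C(=O)OCC)c4)c3c2)cnc1OC` gives 21600 nM in this assay.
Compound 3 `COC(=O)c1cccc(Nc2ncnc3ccc(-c4cnc(OC)c(NS(=O)(=O)c5ccc(F)cc5F)c4)cc23)c1` gives 2800 nM in this assay.

Among these three, compound 1 stands second highest; its number and that of compound 3 lie within the scatter of each other, while compound 2 sits well beyond it, at the weaker end. Compound 4 `CCS(=O)(=O)Nc1cc(-c2ccc3ncnc(Nc4ccc(OC)nc4)c3c2)cnc1OC` has not been measured. It differs from compound 1 in one place: 6-methoxypyridin-3-yl in place of 3,4-dimethoxyphenyl on a nitrogen on an aromatic ring. Among the compounds with values here, no measured pair shows the effect of this exchange, so its size is not known. On the shared core of compound 1, she expects at most a small shift for compound 4 in this assay, none beyond the scatter, as the step of a 1.2-fold higher number from compound 1 to compound 4 (0.09 log units; within the scatter) is estimated. Compound 4 is thus estimated at 3500 nM, within a range from 1200 nM to 10000 nM.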

Compound 4, half-maximal inhibitory concentration: 3440 nM
Compound 4: the middle estimate sits 1.0-fold (0.01 log units) above what was measured, and the stated range covers the measured number.
By their numbers in this assay, from the lowest: compounds 3, 1 and 4 (each within the scatter of the next); then compound 2.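

Putting 6-methoxypyridin-3-yl in place of 3,4-dimethoxyphenyl on a nitrogen on an aromatic ring gives a 1.2-fold higher number from compound 1 to compound 4 (0.08 log units; within the scatter) in this assay on the shared core. This position therefore accepts a smaller group with a hetero atom in its ring while the number stays within the scatter. Nothing available bears on why the two numbers lie so close.

On these data alone, the step changes the ring and the methoxy count together, so their separate contributions remain unknown. Also open, as far as these compounds go, is how an amine or a carboxylic acid would fare on this ring in place of methoxy.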